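The compounds below may be only part of what the source reports. "The series", "measured", "known", "first", "only" and "open" are said of these compounds alone.

Of the compounds shown here, two carrying the same shared core have been measured, and one more remains to be tested. Compound 1 `O=C(c1cc(Oc2cccc(NC(=S)Nc3ccc(F)c(F)c3)c2)ccn1)N1CCCC1` is a thiourea bearing a 3,4-difluorophenyl group. In a functional assay on HCT-116 cells (Homo sapiens) for cytotoxicity, read by MTT assay, with a stated time of 48 h (a higher number here means a weaker inhibitor, a lower number a stronger inhibitor), compound 1 gives 52000 nM. Compound 2 `O=C(c1cc(Oc2cccc(NC(=S)Nc3cccc(C(F)(F)F)c3)c2)ccn1)N1CCCC1` carries a 3-(trifluoromethyl)phenyl group on the same nitrogen instead, and in this assay compound 2 gives 19200 nM. Among the compounds with values here, that single change gave a 2.7-fold lower number from compound 1 to compound 2 (0.43 log units; beyond the scatter), so compound 2 stands as the lower of the two numbers so far.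

Compound 3 `O=C(c1cc(Oc2cccc(NC(=S)Nc3ccc(Cl)c(C(F)(F)F)c3)c2)ccn1)N1CCCC1` differs from compound 2 by one addition: chloro in place of hydrogen on an aromatic carbon. Within the data shown here, the only measured step, a 2.7-fold lower number from compound 1 to compound 2 (0.43 log units; beyond the scatter), touches the same aromatic ring, but it swaps the whole substitution pattern rather than adding a single chloro, so it is at best an indirect guide. Among the measured compounds shown here, no measured pair shows the effect of adding a chlorine to an otherwise unchanged ring. Given that, a modest change in this assay is the most that can be expected, with direction uncertain, and the estimate for compound 3 is 12000 nM, within 5000 nM to 35000 nM. This corresponds to an expected step of a 1.6-fold lower number from compound 2 to compound 3 (0.20 log units; within the scatter).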

Compound 3, half-maximal inhibitory concentration: 22400 nM
Beside the measured number, compound 3's estimate is 1.9-fold (0.27 log units) below it; low and high end bracket the measured number.
By their numbers in this assay, from the lowest: compounds 2 and 3 (each within the scatter of the next); then compound 1.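

Within the data shown here, this result is the first direct look at adding a single atom to this ring: in this assay, chloro in place of hydrogen, on the aromatic carbon ortho to the trifluoromethyl group and para to a large group, gives a 1.2-fold higher number from compound 2 to compound 3 (0.07 log units; within the scatter), so this assay does not separate compound 2 from compound 3. The added chlorine therefore leaves the number within ordinary measurement noise, and the position accepts this one extra atom without a readable cost or gain. The 4-chloro-3-(trifluoromethyl)phenyl group also gives a 2.3-fold lower number from compound 1 to compound 3 (0.37 log units; beyond the scatter), which lies beyond the scatter just as a 2.7-fold lower number from compound 1 to compound 2 (0.43 log units; beyond the scatter) does, while no measurement available here offers an explanation for any of these numbers.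

The compounds shown leave open whether this same carbon would respond differently to another group, such as a methoxy group, an amine or a carboxylic acid. They also leave open whether a chloro group on a different carbon of this ring, or on a ring without the trifluoromethyl group, would give a number that can be told apart from those of compound 2 and compound 3.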